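Swapping the aniline ring: from compound 3 to compound 4

The compounds below may be only part of what the source reports. "The series", "measured", "known", "first", "only" and "open" are said of these compounds alone.

The measured compounds and their numbers:

Compound 1 `Cc1ccc(Nc2nc(SCc3cn(CC(=O)NC(=O)Nc4ccccn4)nn3)nc(-c3ccc(C(C)C)cc3)c2C#N)cc1` — in a functional assay on ECa-109 cells (Homo sapiens) for inhibition, read by MTT assay, with a stated time of 72 h (a higher number here means a weaker inhibitor, a lower number a stronger inhibitor), compound 1 gives 6700 nM
Compound 2 `Cc1ccc(-c2nc(SCc3cn(CC(=O)NC(=O)Nc4ccccn4)nn3)nc(Nc3ccc(C(C)C)cc3)c2C#N)cc1` — compound 2 gives 7450 nM
Compound 3 `COc1ccccc1Nc1nc(SCc2cn(CC(=O)NC(=O)Nc3ccccn3)nn2)nc(-c2ccc(C)cc2)c1C#N` — compound 3 gives 7850 nM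

Compound 3 has the highest of the three numbers, but its neighbours sit close: the nearest is compound 2 and the furthest compound 1, and both gaps are within the scatter of this assay. None of the three can therefore be called stronger or weaker than another.

Compound 4 `Cc1ccc(Nc2nc(SCc3cn(CC(=O)NC(=O)Nc4ccccn4)nn3)nc(-c3ccc(C)cc3)c2C#N)cc1` differs from compound 3 in one place: 4-methylphenyl in place of 2-methoxyphenyl on a nitrogen on an aromatic ring. Among the compounds with values here, one measured step touches this same nitrogen. From compound 2 to compound 3 the ring on that nitrogen was exchanged and this assay moved by a 1.1-fold higher number from compound 2 to compound 3 (0.02 log units; within the scatter), a step within the scatter. Compound 1 carries a 4-methylphenyl on the same nitrogen with a different aryl elsewhere, and its number lies within the scatter of both others. On this basis the exchange of 2-methoxyphenyl for 4-methylphenyl is expected to give no step beyond the scatter, so compound 4 is expected to land at a 1.1-fold lower number from compound 3 to compound 4 (0.05 log units; within the scatter). Compound 4 is estimated at 7000 nM, within a range from 3500 nM to 14000 nM.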

Compound 4, half-maximal inhibitory concentration: > 64000 nM
Compound 4 ended at the assay's limit (the forecaster's own chance of this, stated with the estimate: 5%); middle value at least 9.1-fold (0.96 log units) away from the limit.
By their numbers in this assay, from the lowest: compounds 1, 2 and 3 (each within the scatter of the next). At a limit, above all of these: compound 4.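

In this assay, compound 4 is the only compound at a limit, so its steps give only a lower bound: the limit of > 64000 nM in this assay, at which 1 of the 4 values shown sits.

The ring on a nitrogen on an aromatic ring, which had looked indifferent in a 1.1-fold higher number from compound 2 to compound 3 (0.02 log units; within the scatter), proves able to matter: exchanging 2-methoxyphenyl for 4-methylphenyl gives an at least 8.1-fold higher number from compound 3 to compound 4 (0.91 log units; beyond the scatter). The same sharp loss appears when methyl takes the place of isopropyl on an aromatic carbon on either aryl group, in an at least 8.5-fold higher number from compound 2 to compound 4 (0.93 log units; beyond the scatter) and in an at least 9.5-fold higher number from compound 1 to compound 4 (0.98 log units; beyond the scatter). Among these four compounds, activity in the measurable range goes with carrying either an isopropyl or a methoxy, and compound 4, with 4-methylphenyl on the nitrogen and on the other aryl position, has neither, with no compound here going against this.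

As far as these compounds go, what remains open is how large the loss really is, and whether the methoxy itself or its placement on the ring counts. A 4-methoxyphenyl, a 2-methylphenyl or an unsubstituted phenyl on that nitrogen, paired with the same 4-methylphenyl elsewhere, would separate these readings.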